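Swapping an ester oxygen for sulfur in a dienoate

The compounds below may be only part of what the source reports. "The series", "measured", "known", "first", "only" and "open" are said of these compounds alone.

Of the compounds shown here, two have been measured in a physicochemical assay for lipophilicity; on this read-out higher numbers stand for higher lipophilicity and lower numbers for lower lipophilicity. Compound 1, `CC(/C=C/CC(C)CCCC(C)C)=C\C(=O)OCC(C)C`, gives 7.69, the higher of the two numbers. Compound 2, `C=C(C)CCCC(C)C/C=C/C(C)=C/C(=O)OCC`, gives 6.19, which lies well beyond the scatter below compound 1. Among the compounds with values here, no single-site step between measured compounds exists in this set, so nothing is yet known about how a change at the ester end alone moves this assay.

Compound 3, `CC(/C=C/CC(C)CCCC(C)C)=C\C(=O)SC(C)C`, differs from compound 1 at one place: isopropylsulfanyl in place of isobutoxy on a carbonyl carbon. Seen one bond further out, isobutoxycarbonyl becomes (isopropylsulfanyl)carbonyl.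

Because compound 1 already stands at 7.69, compound 3 is expected to stay close to it, with a step of a number 0.16 log units higher from compound 1 to compound 3 (within the scatter) that may be slightly upward or within the scatter. Compound 3 is therefore estimated at 7.85, in a range from 7.3 to 8.4.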

Compound 3, partition coefficient: 8.39
The estimate for compound 3 lay 0.54 log units below the measured number; low and high end bracket the measured number.
By their numbers in this assay, from the lowest: compound 2; then compound 1; then compound 3.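

Within the data shown here, at this carbonyl carbon, isopropylsulfanyl in place of isobutoxy gives the first single-site reading in this assay: a number 0.70 log units higher from compound 1 to compound 3 (beyond the scatter). The place is therefore not silent on this read-out, even though the entering group has fewer heavy atoms than the leaving one and the counts of hydrogen-bond donors and acceptors stay the same. Nothing measured here accounts for the step.

As far as these compounds go, this one pair changes both the atom bound to the carbonyl carbon and the carbon part of the group, so it remains open how much of the step belongs to each, a question that an isopropoxy or an isobutylsulfanyl group at the same place would address. From the compounds shown here alone, it also remains open how a dimethylamino group on this carbonyl carbon would read, and whether the step would hold on a core other than that of compound 1.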